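The source may report more compounds than this note shows. Statements on the series, on what has been measured and on what is new or still open speak of the compounds shown alone.

Compound 3 `COc1ccc(S(=O)(=O)N2CCc3cccc(NC(C)=O)c32)cc1` carries an acetamido group. Among the compounds with values here, in a functional assay on KB cells (Homo sapiens) for cytotoxicity (on this read-out higher numbers stand for weaker inhibition and lower numbers for stronger inhibition), compound 3 gives 89 nM, the second highest of the three numbers measured so far: compound 1 `COc1ccc(S(=O)(=O)N2CCc3cccc(NC(=O)c4ccncc4)c32)cc1` gives 9.6 nM, while compound 2 `COc1ccc(S(=O)(=O)N2CCc3cccc(NS(=O)(=O)c4ccc(F)cc4)c32)cc1` gives 1200 nM. Compound 4 `COc1ccc(S(=O)(=O)N2CCc3cccc(NC(=O)c4ccccc4)c32)cc1` has not been measured yet; it differs from compound 3 in one place, (phenyl in place of methyl on a carbonyl carbon). The step that bears most on this change is the one with pyridin-4-yl in place of methyl on the same carbonyl carbon, read backwards: a 9.3-fold higher number from compound 1 to compound 3 (0.97 log units; beyond the scatter). Within the data shown here, replacing the methyl with a six-membered aromatic ring is therefore expected to give a large step downward, a 5.9-fold lower number from compound 3 to compound 4 (0.77 log units; beyond the scatter), although no measured step shows how phenyl compares with pyridin-4-yl. Compound 4 is estimated at 15 nM, within 5 nM to 60 nM.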

Compound 4, half-maximal inhibitory concentration: 297 nM
Beside the measured number, compound 4's estimate is 20-fold (1.30 log units) below it; the whole stated range lies below it.
By their numbers in this assay, from the lowest: compound 1; then compound 3; then compound 4; then compound 2.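

In this assay, a six-membered aromatic ring on this carbonyl carbon does not by itself lower the number: phenyl in place of methyl raises it (a 3.3-fold higher number from compound 3 to compound 4 (0.52 log units; beyond the scatter)), and phenyl in place of pyridin-4-yl raises it much further (a 31-fold higher number from compound 1 to compound 4 (1.49 log units; beyond the scatter)). So the identity of the ring matters here, not just its presence. Benzoyl on the nitrogen still gives a lower number than (4-fluorophenyl)sulfonyl (a 4.0-fold lower number from compound 2 to compound 4 (0.61 log units; beyond the scatter)), although nothing measured here explains these differences. On these data alone, whether pyridin-3-yl would match pyridin-4-yl remains open. So does whether a longer chain such as propyl would do better or worse than methyl.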